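Replacing the thiazolyl pyrrolidinone group of compound 3

The compounds below may be only part of what the source reports. "The series", "measured", "known", "first", "only" and "open" are said of these compounds alone.

Measured in a toxicity assay on HepG2 2.2.15 cells (Homo sapiens) for cytotoxicity, read by CellTiter-Glo; on this read-out higher numbers stand for lower toxicity in this test and lower numbers for higher toxicity in this test:
compound 1 `O=C1OC(c2ccccc2)CN1c1cnn2c1CN(C(=O)Nc1cc(F)c(F)c(F)c1)C(C1CC1)C2`: 7410 nM
compound 2 `O=C1CC(C(F)(F)F)CN1c1cnn2c1CN(C(=O)Nc1cc(F)c(F)c(F)c1)C(C1CC1)C2`: 115000 nM
compound 3 `Cc1cnc(C2CC(=O)N(c3cnn4c3CN(C(=O)Nc3cc(F)c(F)c(F)c3)C(C3CC3)C4)C2)s1`: 96200 nM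

Compound 3 stands at the high end of these numbers, level with its nearest neighbour: a 1.2-fold lower number from compound 2 to compound 3 (0.08 log units; within the scatter). The gap to the far end is wide: a 13-fold higher number from compound 1 to compound 3 (1.11 log units; beyond the scatter). Compound 4 `O=C1c2ccccc2CN1c1cnn2c1CN(C(=O)Nc1cc(F)c(F)c(F)c1)C(C1CC1)C2` brings a change at the same place: a group of 10 heavy atoms (8 carbon, 1 nitrogen, 1 oxygen; one five-membered non-aromatic ring with 1 hetero atom, one six-membered aromatic ring of carbon only) in place of a group of 12 heavy atoms (8 carbon, 2 nitrogen, 1 oxygen, 1 sulfur; one five-membered non-aromatic ring with 1 hetero atom, one five-membered aromatic ring with 2 hetero atoms), on an aromatic carbon. The other large step runs the same way: a 16-fold higher number from compound 1 to compound 2 (1.19 log units; beyond the scatter). Only compound 1, at 7410 nM, holds a six-membered aromatic ring of carbon only in this group, as compound 4 does. A moderately lower number is therefore expected in this assay, on thin evidence. The expected step is a 3.2-fold lower number from compound 3 to compound 4 (0.51 log units; beyond the scatter). For compound 4 the estimate is 30000 nM, with an expected range of 8000 nM to 110000 nM.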

Compound 4, half-maximal cytotoxic concentration: 38500 nM
Compound 4: the middle estimate sits 1.3-fold (0.11 log units) below what was measured, and the stated range covers the measured number.
By their numbers in this assay, from the lowest: compound 1; then compound 4; then compounds 3 and 2 (each within the scatter of the next).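

In this assay the group of compound 4 gives a 2.5-fold lower number from compound 3 to compound 4 (0.40 log units; beyond the scatter) and a 3.0-fold lower number from compound 2 to compound 4 (0.48 log units; beyond the scatter) and also a 5.2-fold higher number from compound 1 to compound 4 (0.72 log units; beyond the scatter) as its step from the other compound holding a six-membered aromatic ring of carbon only. Such a ring at this position therefore does not by itself bring the number down to that of compound 1; compound 4 holds one too and sits in between. Nothing measured here accounts for these steps.

On these data alone, whether an amine or a carboxylic acid on that six-membered aromatic ring would move the number stays open.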